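Methoxy for Methyl: Estimating Compound 4

This account rests on a few compounds, and the source may have more. Where it says the series, first, only, none or still open, it means among the compounds named here.

Compound 1 `Cc1ccc(S(=O)(=O)c2nc3ccccc3nc2N2CCc3ccccc3C2)cc1` and compound 2 `COc1ccc(S(=O)(=O)c2nc3ccccc3nc2N2CCc3ccccc3C2)cc1` share a core and differ by methoxy in place of methyl on an aromatic carbon. In a functional assay on HCT-116 cells (Homo sapiens) for cytotoxicity, read by MTT assay, with a stated time of 72 h (a higher number here means a weaker inhibitor, a lower number a stronger inhibitor), compound 1 gives 39000 nM and compound 2 gives 22100 nM, a step of a 1.8-fold lower number from compound 1 to compound 2 (0.25 log units; within the scatter). Compound 3 `Cc1ccc(S(=O)(=O)c2nc3ccccc3nc2N2CCCC(O)C2)cc1` carries a different group on the shared core: 3-hydroxypiperidin-1-yl in place of 1,2,3,4-tetrahydroisoquinolin-2-yl on an aromatic carbon. In this assay compound 3 gives 3270 nM, a step of a 12-fold lower number from compound 1 to compound 3 (1.08 log units; beyond the scatter). Compound 4 `COc1ccc(S(=O)(=O)c2nc3ccccc3nc2N2CCCC(O)C2)cc1` stands to compound 3 as compound 2 stands to compound 1, differing by methoxy in place of methyl on an aromatic carbon; the surroundings of the change are the same in both pairs, so it is the same change on a different core. Because the earlier step of a 1.8-fold lower number from compound 1 to compound 2 (0.25 log units; within the scatter) was small, a step of similar size, a 1.3-fold lower number from compound 3 to compound 4 (0.12 log units; within the scatter), is expected for compound 4. Compound 4 is therefore estimated at 2500 nM, with a likely range of 1200 nM to 5500 nM.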

Compound 4, half-maximal inhibitory concentration: 3520 nM
Beside the measured number, compound 4's estimate is 1.4-fold (0.15 log units) below it; measured number inside the range.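

In this assay, methoxy in place of methyl on the core of compound 3 gives a 1.1-fold higher number from compound 3 to compound 4 (0.03 log units; within the scatter), so the change again has no clear effect, and the two cores agree: the same change on two cores in this assay, a 1.8-fold lower number (0.25 log units; within the scatter) from compound 1 to compound 2 and a 1.1-fold higher number (0.03 log units; within the scatter) from compound 3 to compound 4, 1.9-fold (0.28 log units) apart, within the scatter of two such steps. The swap of 1,2,3,4-tetrahydroisoquinolin-2-yl for 3-hydroxypiperidin-1-yl also carries over, with a 6.3-fold lower number from compound 2 to compound 4 (0.80 log units; beyond the scatter): the same change on two cores in this assay, a 12-fold lower number (1.08 log units; beyond the scatter) from compound 1 to compound 3 and a 6.3-fold lower number (0.80 log units; beyond the scatter) from compound 2 to compound 4, 1.9-fold (0.28 log units) apart, within the scatter of two such steps. This supports the two changes acting independently across these four compounds, but a step lost in the scatter on both cores is weak proof of transfer, and two cores set no rule for the series.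

Still open, as far as these compounds go, is whether a group that differs more from methyl, such as an amine or a carboxylic acid, would behave alike on both cores. From the compounds shown here alone, whether the hydroxy group of the piperidine matters also remains unknown.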